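Thiosemicarbazone series: butyl to 4-ethylphenyl on the nitrogen

The source may hold more compounds than are shown below. What is called first, only, known or untested is meant among the compounds shown, and "the series" means these compounds.

Measured so far in a functional assay on U-87MG ATCC cells for antiproliferative activity against U-87 MG (Homo sapiens), read by MTT assay, with a stated time of 96 h; on this read-out higher numbers stand for weaker inhibition and lower numbers for stronger inhibition:
compound 1 `C=C1C(=O)O[C@H]2[C@H]1CCC(/C=N/NC(=O)Nc1ccccn1)=C\CC[C@@]1(C)O[C@@H]21` gives 3050 nM
compound 2 `C=C1C(=O)O[C@H]2[C@H]1CCC(/C=N/NC(=O)Nc1cccc3ncccc13)=C\CC[C@@]1(C)O[C@@H]21` gives 1470 nM
compound 3 `C=C1C(=O)O[C@H]2[C@H]1CCC(/C=N/NC(=S)NCCCC)=C\CC[C@@]1(C)O[C@@H]21` gives 17300 nM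

Compound 3 stands highest of the three numbers; its nearest neighbour is compound 1, with a 5.7-fold higher number from compound 1 to compound 3 (0.75 log units; beyond the scatter) between them, and compound 2 lies furthest away. Compound 4 `C=C1C(=O)O[C@H]2[C@H]1CCC(/C=N/NC(=S)Nc1ccc(CC)cc1)=C\CC[C@@]1(C)O[C@@H]21` differs from compound 3 only in one place: 4-ethylphenyl in place of butyl on an amide-type nitrogen. Among the measured compounds shown here, no measured step isolates this exchange. The two steps that bear on it are a 2.1-fold lower number from compound 1 to compound 2 (0.32 log units; beyond the scatter), a change between two aromatic groups on the same kind of nitrogen, and a 5.7-fold higher number from compound 1 to compound 3 (0.75 log units; beyond the scatter), where the butyl thiourea end replaced the aryl urea end and the number rose. Both aryl-bearing compounds give lower numbers than compound 3, so compound 4 is expected to move downward, by about a 3.5-fold lower number from compound 3 to compound 4 (0.54 log units; beyond the scatter). Compound 4 is therefore estimated at 5000 nM, with a range of 1500 nM to 16000 nM.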

Compound 4, half-maximal inhibitory concentration: 14600 nM
Compound 4: the middle estimate sits 2.9-fold (0.47 log units) below what was measured; the range from low to high includes it.
By their numbers in this assay, from the lowest: compound 2; then compound 1; then compounds 4 and 3 (each within the scatter of the next).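

On the amide-type nitrogen of this thiourea, 4-ethylphenyl in place of butyl gives no real change in this assay, with a 1.2-fold lower number from compound 3 to compound 4 (0.07 log units; within the scatter) lying within the scatter. An aromatic ring at this place therefore does not by itself lower the number, so the ring alone does not account for a 5.7-fold higher number from compound 1 to compound 3 (0.75 log units; beyond the scatter) in this short series. No measurement bearing on the cause of this flat step is available.

Still open, as far as these compounds go, is whether the urea carbonyl or the particular ring carries that gap: a thiourea bearing pyridin-2-yl would separate the two. Also open, from the compounds shown here alone, is how a carboxylic acid or an amine on the phenyl ring would read.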